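From 4-methoxyphenyl to pyridin-3-yl on an amine nitrogen

A few compounds are considered here, and "the series" means these few. Any claim that something is new, unique, unknown or untested is made for them only; others in the source may bear on it.

Measured in a physicochemical assay for solubility, read by HPLC; on this read-out higher numbers stand for higher solubility and lower numbers for lower solubility:
Compound 1 `COc1ccc(NC[C@H](O)COc2ccc(N3C[C@H](CNC(C)=O)OC3=O)cc2F)cc1` gives 56000 nM
Compound 2 `CC(=O)NC[C@H]1CN(c2ccc(OC[C@@H](O)CNc3ccccc3)c(F)c2)C(=O)O1` gives 124000 nM
Compound 3 `CC(=O)NC[C@H]1CN(c2ccc(OC[C@H](O)CNc3ccccc3)c(F)c2)C(=O)O1` gives 296000 nM

Compound 1 stands lowest of these three, so a higher number is the likely direction for anything compared with it. Its closest neighbour is compound 2, and compound 3 lies furthest away.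

The compound still to be measured is compound 4 (`CC(=O)NC[C@H]1CN(c2ccc(OC[C@@H](O)CNc3cccnc3)c(F)c2)C(=O)O1`), which carries pyridin-3-yl in place of 4-methoxyphenyl on an amine nitrogen. Two measured steps can be weighed against this change. The first, a 2.2-fold higher number from compound 1 to compound 2 (0.35 log units; beyond the scatter), bears on it directly. That step also removes the methoxy group while the rest of the molecule stays the same. The second, a 2.4-fold higher number from compound 2 to compound 3 (0.38 log units; beyond the scatter), comes with the fact that compounds 2 and 3 differ only in the configuration as drawn, and compound 4 is drawn like compound 2 at that centre, so this step plays no part here. Among the compounds with values here, no measured pair swaps a carbon-only ring for pyridin-3-yl, and that part of the change stays open, which widens the range.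

A modest rise in this assay is therefore expected, similar to or somewhat larger than the first step. The expected change is a 3.2-fold higher number from compound 1 to compound 4 (0.51 log units; beyond the scatter). For compound 4 the estimated value is 180000 nM, with an expected range from 80000 nM to 450000 nM.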

Compound 4, solubility: 3040000 nM
Compound 4: middle estimate off by 17-fold (1.23 log units), on the low side; the whole stated range lies below it.
By their numbers in this assay, from the lowest: compound 1; then compound 2; then compound 3; then compound 4.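

The cleanest reading of this position comes from compounds that differ only in the ring on the amine nitrogen: in this assay, pyridin-3-yl in place of phenyl, a six-membered aromatic ring of carbon only giving way to one with a nitrogen as its hetero atom, gives a 25-fold higher number from compound 2 to compound 4 (1.39 log units; beyond the scatter). That step is much larger than the one for removing the methoxy group, so the ring swap, rather than the loss of methoxy, accounts for most of the whole change from 4-methoxyphenyl to pyridin-3-yl, which is a 54-fold higher number from compound 1 to compound 4 (1.73 log units; beyond the scatter). The step of a 10-fold higher number from compound 3 to compound 4 (1.01 log units; beyond the scatter) is also large, but it is harder to read, as it changes the ring and the drawn configuration together, and configuration alone already shifted the number, as this shows: the fact that compounds 2 and 3 differ only in the configuration as drawn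

Going by these compounds, whether pyridin-2-yl, pyridin-4-yl or pyrimidin-5-yl on the same amine nitrogen would give a step of similar size remains open. Also open, on these data alone, is whether pyridin-3-yl gives the same step in the configuration of compound 3, and whether a methoxy group on the pyridine ring would take part of the rise back.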